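This account rests on a few compounds, and the source may have more. Where it says the series, first, only, none or still open, it means among the compounds named here.

Measured so far in a functional assay on HOP-62 cells (Homo sapiens) for inhibition, read by sulforhodamine B assay, with a stated time of 48 h, tested at 10 uM; on this read-out higher numbers stand for more inhibition of growth at the one concentration tested and lower numbers for less inhibition of growth:

compound 1 `C/C(=N\O)c1ccc(NC(=O)Cn2nc(-c3ccc(Cl)cc3)nc2N)cc1`: 11.7%
compound 2 `COc1cc(-c2nc(N)n(CC(=O)Nc3ccc(/C(C)=N\O)cc3)n2)cc(OC)c1OC`: 5.54%
compound 3 `C/C(=N/O)c1ccc(NC(=O)Cn2nc(-c3ccccc3)nc2N)cc1`: 17.7%

Compound 1 stands second highest among the three numbers, but its nearest neighbour, compound 3, lies within the scatter of it, and so does compound 2; all three values sit low and cannot be told apart.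

Compound 4 `CC(=O)c1ccc(NC(=O)Cn2nc(-c3ccc(Cl)cc3)nc2N)cc1` is the next one to be tested. It differs from compound 1 in one place: a group of 3 heavy atoms (2 carbon, 1 oxygen; no ring) in place of a group of 4 heavy atoms (2 carbon, 1 nitrogen, 1 oxygen; no ring), on an aromatic carbon

For the measured compounds named here, no step between two measured compounds is available to guide the step from compound 1 to compound 4. Since every measured value here is low and indistinguishable, the step of a number 0.3 percentage points higher from compound 1 to compound 4 (within the scatter) is expected to stay within the scatter. Compound 4 is estimated at 12%, with a range from 0% to 28%.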

Compound 4, percent growth inhibition at one concentration: 15.1%
Compound 4: middle estimate off by 3.1 percentage points, on the low side, and the stated range covers the measured number.
By their numbers in this assay, from the lowest: compounds 2, 1, 4 and 3 (each within the scatter of the next, the first and the last beyond it).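

In this assay, acetyl in place of the group of 4 heavy atoms, on the aromatic carbon para to a large group, gives a number 3.4 percentage points higher from compound 1 to compound 4 (within the scatter). At this position, then, exchanging that group for acetyl, which also removes its hydrogen-bond donor, does not separate the two compounds, and both remain low on this read-out. No measurement at hand bears on this result.

On these data alone, whether an amine or a carboxylic acid on this carbon would move the number beyond the scatter remains open. So does whether acetyl would behave alike in compound 2 or compound 3.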